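From piperidin-1-yl to (1-phenylethyl)amino on a carbonyl carbon

A few compounds are considered here, and "the series" means these few. Any claim that something is new, unique, unknown or untested is made for them only; others in the source may bear on it.

Measured in a functional assay on MCF7 cells (Homo sapiens) for antiproliferative activity, read by MTT assay, with a stated time of 24 h; on this read-out lower numbers stand for stronger inhibition and higher numbers for weaker inhibition:
- Compound 1 `CCCCc1oc2ccccc2c1C(=O)c1ccc(OCC(N)=O)cc1`: > 50000 nM (a limit of the assay, not a number)
- Compound 2 `CCCCc1oc2ccccc2c1C(=O)c1ccc(OCCCC(=O)N2CCCCC2)cc1`: 33000 nM

Among the measured compounds shown here, compound 2 holds the only actual number in this small set, at 33000 nM. The result for compound 1 is a limit of the assay. Compound 3 `CCCCc1oc2ccccc2c1C(=O)c1ccc(OCCCC(=O)N[C@H](C)c2ccccc2)cc1` has not yet been measured. It carries (1-phenylethyl)amino in place of piperidin-1-yl on a carbonyl carbon.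

For the measured compounds named here, one measured step bears on this change, and it too involves the (piperidin-1-yl)carbonyl group: an at least 1.5-fold lower number from compound 1 to compound 2 (0.18 log units; that floor lies within the scatter). That step is a floor and says little about the size of a change at this carbonyl carbon. Going by the values given here, no measured step yet replaces piperidin-1-yl itself. Only that floor is there to go on. With compound 2 at 33000 nM, no step beyond the scatter is expected in this assay. The estimated step is a 1.3-fold lower number from compound 2 to compound 3 (0.12 log units; within the scatter). For compound 3 the expected value is 25000 nM, with an estimated range from 10000 nM to 50000 nM.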

Compound 3, half-maximal inhibitory concentration: > 50000 nM
Compound 3 gave a limit, no number (the forecaster's own chance of this, stated with the estimate: 25%); middle value at least 2.0-fold (0.30 log units) away from the limit.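

In this assay, the change from piperidin-1-yl to (1-phenylethyl)amino on a carbonyl carbon is the only step shown that replaces piperidin-1-yl itself, and it gives an at least 1.5-fold higher number from compound 2 to compound 3 (0.18 log units; that floor lies within the scatter) in this small set. Compound 3 gives > 50000 nM as a limit of the assay and not as a number. The entering group, with its six-membered aromatic ring of carbon only and its hydrogen-bond donor, brings no measurable gain at this position, and the size of any loss cannot be read: the limit of > 50000 nM in this assay, at which 2 of the 3 values shown sit.

As far as these compounds go, it remains open whether a different amine on this carbonyl carbon, such as morpholine, dimethylamine or benzylamine, or the opposite stereoisomer of (1-phenylethyl)amino, would give a number rather than a limit in this assay. From the compounds shown here alone, a carboxylic acid in place of the amide, or a longer chain between the oxygen on the aromatic ring and the carbonyl, is equally open, and so is whether either would improve on compound 2 with its 33000 nM in the same assay.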